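Swapping the carboxy group of compound 2 for a methyl oxime

The compounds below may be only part of what the source reports. "The series", "measured", "known", "first", "only" and "open" are said of these compounds alone.

Of the compounds shown here, two built on the same core have been tested so far. Compound 1 `CO[C@H]1C[C@H](O[Si](C)(C)C(C)(C)C)O[C@@H](C)/C1=C\C=N\O` and compound 2 `CO[C@H]1C[C@H](O[Si](C)(C)C(C)(C)C)O[C@@H](C)/C1=C\C(=O)O` differ only at the chain hanging off the ring: the step of no change at the digits printed from compound 1 to compound 2 (within the scatter) replaced a group of 3 heavy atoms (1 carbon, 1 nitrogen, 1 oxygen; no ring) with a group of 3 heavy atoms (1 carbon, 2 oxygen; no ring), on a double-bonded chain carbon bound to a double-bonded ring carbon. In a functional assay on the whole organism for inhibition, with Artemia salina as the target (on this read-out higher numbers stand for weaker inhibition of growth and lower numbers for stronger inhibition of growth), compound 1 gives 0.002 ug/mL, and in this assay compound 2 gives 0.002 ug/mL, so compound 2 stands level with compound 1.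

Compound 3 `CO/N=C/C=C1\[C@H](C)O[C@@H](O[Si](C)(C)C(C)(C)C)C[C@@H]1OC` is the next variation at the same spot. The change is a group of 4 heavy atoms (2 carbon, 1 nitrogen, 1 oxygen; no ring) in place of a group of 3 heavy atoms (1 carbon, 2 oxygen; no ring), on a double-bonded chain carbon bound to a double-bonded ring carbon. Among the compounds with values here, the one measured step at this position, from compound 1 to compound 2, produced no change beyond the scatter, so a further swap here is expected to leave the read-out essentially where it is, with the step of no change at the digits printed from compound 2 to compound 3 (within the scatter) expected to stay within the scatter. Compound 3 is therefore estimated at 0.002 ug/mL in this assay, with a range from 0.001 ug/mL to 0.004 ug/mL.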

Compound 3, minimum inhibitory concentration: 0.01 ug/mL
Compound 3: middle estimate off by 2.3 two-fold dilutions, on the low side; measured number outside the range, above it.
By their numbers in this assay, from the lowest: compounds 1 and 2 (each within the scatter of the next); then compound 3.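

In this assay, within the data shown here, this position turns out to be less forgiving than the first pair of compounds suggested. Replacing the carboxy group with the methyl oxime gives a number 2.3 two-fold dilutions higher from compound 2 to compound 3 (beyond the scatter), and on this read-out a higher number means weaker inhibition of growth. The smallest edit in the set, methyl in place of hydrogen on an oxygen, gives a number 2.3 two-fold dilutions higher from compound 1 to compound 3 (beyond the scatter), so a single added methyl moves the read-out beyond the scatter, whereas the swap from compound 1 to compound 2 did not, and no measurement offered here explains why the number rose.

These three compounds cannot show whether the added size on the oxygen matters or whether the loss of the hydrogen on that oxygen does. A methyl ester in place of the carboxy group would test whether the same methyl has a similar effect on the acid, while an ethyl or benzyl group on the oxime oxygen would show whether the number keeps rising as that group grows.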